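Compound 4: aminomethyl in place of hydroxymethyl

A few compounds are considered here, and "the series" means these few. Any claim that something is new, unique, unknown or untested is made for them only; others in the source may bear on it.

Three measured compounds share one core and differ only in the aryl group on the carbonyl carbon. Compound 1 `Cc1cccc(C(=O)c2ccn(-c3ccc4c(c3)B(O)OC4)c2)c1` carries a 3-methylphenyl there; in an ADME assay on L929 cells (Mus musculus) for cytotoxicity, read by resazurin assay, with a stated time of 72 h (on this read-out lower numbers stand for stronger inhibition and higher numbers for weaker inhibition), compound 1 gives only a limit, > 10 ug/mL. Compound 2 `COc1ccc(C(=O)c2ccn(-c3ccc4c(c3)B(O)OC4)c2)cc1` carries a 4-methoxyphenyl, and in this assay compound 2 likewise gives a limit, > 10 ug/mL. Among the measured compounds shown here, compound 3 `O=C(c1ccc(CO)cc1)c1ccn(-c2ccc3c(c2)B(O)OC3)c1` carries a 4-(hydroxymethyl)phenyl, and in this assay compound 3 gives 9.31 ug/mL, the only number among the three. The step of an at least 1.0-fold lower number from compound 1 to compound 3 (0.03 log units; that floor lies within the scatter) and the step of an at least 1.0-fold lower number from compound 2 to compound 3 (0.03 log units; that floor lies within the scatter) are both floors lying within the scatter, and the step that the two limits leave unreadable from compound 1 to compound 2 cannot be read at all; the limit of > 10 ug/mL in this assay, at which 2 of the 3 values shown sit, covers both of its ends.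

Compound 4 `NCc1ccc(C(=O)c2ccn(-c3ccc4c(c3)B(O)OC4)c2)cc1` is not yet measured. It differs from compound 3 by amino in place of hydroxy on a saturated chain carbon bound to an aromatic carbon. For the measured compounds named here, no measured step touches this change, and the two steps that lead to compound 3 are floors within the scatter, so nothing in the measured set points to a step beyond the scatter. Compound 4 is therefore expected in this assay to give about 10 ug/mL, between 5 ug/mL and 20 ug/mL, and a report of a limit rather than a number would be no surprise. The step of a 1.1-fold higher number from compound 3 to compound 4 (0.03 log units; within the scatter) is expected to stay within the scatter.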

Compound 4, half-maximal inhibitory concentration: > 10 ug/mL
Compound 4: a limit, no number; the forecaster's own chance of this, stated with the estimate: 50%; the middle value lies on the limit itself.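

In this assay, amino in place of hydroxy on a saturated chain carbon bound to an aromatic carbon gives an at least 1.0-fold higher number from compound 3 to compound 4 (0.03 log units; that floor lies within the scatter), so this first change made on that chain carbon shows no step beyond the scatter, although its true size cannot be read. Compound 4 gives a limit and not a number, and the steps from compound 1 and from compound 2 to compound 4 cannot be read, as both ends of each are limits. Compound 3 therefore remains the only compound with a number, and the set offers little means of telling these aryl groups apart: the limit of > 10 ug/mL in this assay, at which 3 of the 4 values shown sit.

The compounds shown leave open how far the true values of compound 1, compound 2 and compound 4 lie from that limit, and so whether amino and hydroxy differ at all on this chain carbon. Also open, as far as these compounds go, is how a carboxylic acid, a dimethylaminomethyl group or a longer chain ending in an amine would read in this assay in place of the aminomethyl.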